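Extending the methylamino chain on a chlorotriazine herbicide

The compounds below may be only part of what the source reports. "The series", "measured", "known", "first", "only" and "open" are said of these compounds alone.

Compound 1 `CNc1nc(Cl)nc(N[C@@H](C)c2ccccc2)n1` stands highest of the three numbers in an ADME assay on the whole organism for inhibition, with Echinochloa crus-galli var. formosensis as the target, with a stated time of 4 days (a lower number here means a stronger inhibitor, a higher number a weaker inhibitor), where compound 1 gives 26900 nM. Compound 2 `CC(C)N(c1nc(Cl)nc(N[C@H](C)c2ccccc2)n1)C(C)C` gives 6610 nM, and compound 3 `CNc1nc(Cl)nc(N[C@H](C)c2ccccc2)n1` gives 562 nM. Compound 4 `CCCNc1nc(Cl)nc(N[C@@H](C)c2ccccc2)n1` differs from compound 1 by ethyl in place of hydrogen on a saturated chain carbon bound to a nitrogen on an aromatic ring. Of the measured steps, only a 12-fold lower number from compound 2 to compound 3 (1.07 log units; beyond the scatter) concerns the group on the aromatic nitrogen, and there the smaller methylamino gave the lower number; the step of a 48-fold lower number from compound 1 to compound 3 (1.68 log units; beyond the scatter) rests on configuration alone the fact that compounds 1 and 3 differ only in the configuration as drawn and does not bear on this change. Propylamino is a smaller move than diisopropylamino, so a modest rise in the number is expected, a 1.5-fold higher number from compound 1 to compound 4 (0.17 log units; within the scatter). Compound 4 is therefore estimated at 40000 nM, within 13000 nM to 120000 nM.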

Compound 4, half-maximal inhibitory concentration: 15100 nM
Compound 4: the middle estimate sits 2.6-fold (0.42 log units) above what was measured, within the range that was stated.
By their numbers in this assay, from the lowest: compound 3; then compound 2; then compounds 4 and 1 (each within the scatter of the next).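

In this assay the change from methylamino to propylamino on the configuration of compound 1 gives a 1.8-fold lower number from compound 1 to compound 4 (0.25 log units; within the scatter) and so this position accepts the longer chain with no shift beyond the scatter. The earlier step at this position, a 12-fold lower number from compound 2 to compound 3 (1.07 log units; beyond the scatter) on the opposite drawn configuration, involved diisopropylamino and was large. Nothing known here accounts for this result. As far as these compounds go, whether propylamino behaves the same way on the configuration of compound 3 remains open. Also open, from the compounds shown here alone, is how a butylamino chain or a hydroxyethylamino group would fare at this position.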